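This account rests on a few compounds, and the source may have more. Where it says the series, first, only, none or still open, it means among the compounds named here.

Of the compounds shown here, two built on one shared core have been tested in a functional assay on the whole organism for inhibition, with Rattus norvegicus as the target, read by paw edema, with stated times of 1 h and 7 h, at a dose of 100 mg/kg by the oral route; on this read-out higher numbers stand for more inhibition at the one dose given (going by the name of the read-out) and lower numbers for less inhibition. Compound 1 `O=C(CNc1nc(-c2ccccc2)c(-c2ccccc2)s1)N1CCOCC1` gives 59.8% in this assay, and compound 2 `CN1CCN(C(=O)CNc2nc(-c3ccccc3)c(-c3ccccc3)s2)CC1` gives 54.3%. Compound 2 holds the lower of the two numbers shown, but the step of a number 5.5 percentage points lower from compound 1 to compound 2 (within the scatter) is within the scatter, so the two compounds cannot be told apart on these data. Compound 3 `O=C(O)CNc1nc(-c2ccccc2)c(-c2ccccc2)s1` carries the change (hydroxy in place of 4-methylpiperazin-1-yl on a carbonyl carbon). Within the data shown here, only one measured step bears on it: the step from compound 1 to compound 2 also altered the group on that carbonyl carbon, and it was small. The change to compound 3 is of a different kind, so that step is only a loose guide. The step of a number 9.3 percentage points lower from compound 2 to compound 3 (within the scatter) is therefore expected to be modest, with its direction uncertain. Compound 3 is estimated to give 45% in this assay, with a range from 15% to 70%.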

Compound 3, a percentage reported as inhibition, in the whole organism at one dose (the size of the read-out at that dose, not a potency): 54%
Compound 3: middle estimate off by 9 percentage points, on the low side, and the stated range covers the measured number.
By their numbers in this assay, from the lowest: compounds 3, 2 and 1 (each within the scatter of the next).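

Hydroxy on this carbonyl carbon, which turns the amide into a carboxy group, is a much larger change than the earlier swap of one ring for another, since the whole ring leaves. Even so, this assay shows a number 0.3 percentage points lower from compound 2 to compound 3 (within the scatter) and a number 5.8 percentage points lower from compound 1 to compound 3 (within the scatter) as well, so among these three compounds a ring on the carbonyl carbon is not needed for this read-out at the one dose given. No measurement at hand explains why these compounds cannot be told apart.

Going by these compounds, whether a methyl ester or a plain amino group on the same carbonyl carbon would also stay within the scatter remains open. So does the effect of a longer chain in place of the saturated chain carbon that carries the carbonyl group.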